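A few compounds are considered here, and "the series" means these few. Any claim that something is new, unique, unknown or untested is made for them only; others in the source may bear on it.

In a functional assay on A549 cells (Homo sapiens) for antiproliferative activity, read by MTT assay, with a stated time of 72 h (on this read-out lower numbers stand for stronger inhibition and higher numbers for weaker inhibition), three compounds sharing one core have been measured. Compound 1 `COc1cc(-n2cnc3ccc(-c4ccc(C(C)=O)cc4)cc32)cc(OC)c1OC`, which carries 4-acetylphenyl, gives 2510 nM. Compound 2 `COc1ccc(-c2ccc3ncn(-c4cc(OC)c(OC)c(OC)c4)c3c2)cc1O`, which carries 3-hydroxy-4-methoxyphenyl, gives 200 nM. Compound 3 `COc1cc(-n2cnc3ccc(-c4cccc(O)c4)cc32)cc(OC)c1OC`, which carries 3-hydroxyphenyl, gives 250 nM. Compound 3 therefore stands level with compound 2, the gap being a 1.3-fold higher number from compound 2 to compound 3 (0.10 log units; within the scatter), and well clear of compound 1, the gap there being a 10-fold lower number from compound 1 to compound 3 (1.00 log units; beyond the scatter).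

Compound 4 `COc1cc(-n2cnc3ccc(-c4cccc(C)c4)cc32)cc(OC)c1OC` has methyl in place of hydroxy on an aromatic carbon, meta to a large group, turning 3-hydroxyphenyl into 3-methylphenyl: methyl in place of hydroxy on an aromatic carbon. Within the data shown here, no measured step makes this exchange alone. The nearest evidence is the other step away from compound 1, a 13-fold lower number from compound 1 to compound 2 (1.10 log units; beyond the scatter). Like the step to compound 3, it brings in hydroxy but also removes 4-acetylphenyl. The measurements do not separate these two changes. Loss of methoxy from compound 2 changed nothing beyond the scatter, and that step says nothing about hydroxy. A modest rise in this assay is therefore expected, with wide uncertainty, and the expected step is a 1.8-fold higher number from compound 3 to compound 4 (0.26 log units; within the scatter). For compound 4 the estimated value is 450 nM, with an expected range of 130 nM to 1600 nM.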

Compound 4, half-maximal inhibitory concentration: 3820 nM
Compound 4: middle estimate off by 8.5-fold (0.93 log units), on the low side, outside the stated range (above it).
By their numbers in this assay, from the lowest: compounds 2 and 3 (each within the scatter of the next); then compounds 1 and 4 (each within the scatter of the next).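

The exchange of hydroxy for methyl, meta to a large group, can now be read on its own in this assay and gives a 15-fold higher number from compound 3 to compound 4 (1.18 log units; beyond the scatter) as a large step, so the hydroxy of compound 3 counts for much in itself, a share that the steps away from compound 1 could not separate from the loss of 4-acetylphenyl. The comparison with the other hydroxy compound points the same way, with a 19-fold higher number from compound 2 to compound 4 (1.28 log units; beyond the scatter) also large, whereas a 1.5-fold higher number from compound 1 to compound 4 (0.18 log units; within the scatter) stays within the scatter, so that among these four compounds the two bearing hydroxy lie together at the low end and the two without it together at the high end, with none going against this. Nothing at hand speaks to the reason for the size of this step.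

As far as these compounds go, whether an amine, a hydroxymethyl group or a carboxylic acid on this carbon would stay with compound 3 or fall back to compound 4 remains open. From the compounds shown here alone, it is also open whether a hydroxy on another carbon of this ring would hold the same level, and whether the large step on 3-methylphenyl would recur in other cells.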